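This account rests on a few compounds, and the source may have more. Where it says the series, first, only, none or still open, it means among the compounds named here.

Four compounds built on one shared scaffold are compared here, each carrying two aryl groups joined through a chain that holds a carbonyl and an amine nitrogen. Compound 1 `COc1cc(/C=C/C(=O)/C=C(/C=C/c2ccc(OC(C)=O)c(OC)c2)NC2CCCCC2)ccc1OC(C)=O` and compound 2 `COc1cc(/C=C/C(=O)/C=C(/C=C/c2ccc(OC(C)=O)c(OC)c2)NCC(C)C)ccc1OC(C)=O` bear acetylated phenols; compound 3 `COc1cc(/C=C/C(=O)/C=C(/C=C/c2ccc(O)c(OC)c2)NC2CCCCC2)ccc1O` and compound 4 `COc1cc(/C=C/C(=O)/C=C(/C=C/c2ccc(O)c(OC)c2)NCC(C)C)ccc1O` bear free phenols instead.

In a functional assay for inhibition, read by spectrophotometry, with a stated time of 30 min, tested at 1 uM (a higher number here means more inhibition at the concentration tested (going by the name of the read-out), a lower number less inhibition), compound 1 gives 0.01%, and compound 2 gives 0%. The change between them, (isobutyl in place of cyclohexyl on an amine nitrogen), produces a step of a number 0 percentage points lower from compound 1 to compound 2 (within the scatter), so at this concentration neither compound shows meaningful inhibition. Compound 3, in this assay, gives 0.13%, a value that sits within the scatter of both earlier numbers. How the core of compound 3 differs from the core of compound 1 is not broken down here.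

Compound 4 is reached from compound 3 by the same change already seen between compound 1 and compound 2, namely (isobutyl in place of cyclohexyl on an amine nitrogen), and the place is the same word for word. Because the earlier step of a number 0 percentage points lower from compound 1 to compound 2 (within the scatter) stayed within the scatter, and because compound 3 already gives 0.13%, compound 4 is expected to show little inhibition at this concentration as well, with an estimated step of a number 0 percentage points lower from compound 3 to compound 4 (within the scatter). The estimated value for compound 4 in this assay is 0.1%, with an expected range from 0% to 8%.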

Compound 4, a percentage reported as inhibition, at one concentration (the size of the read-out at that concentration, not a potency): 0.09%
Beside the measured number, compound 4's estimate is 0 percentage points above it; the measured number falls inside the stated range.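

In this assay, isobutyl in place of cyclohexyl on the amine nitrogen of the free-phenol core gives a number 0 percentage points lower from compound 3 to compound 4 (within the scatter) and matches what the same swap gives on the acetylated core: the same change on two cores in this assay, a number 0 percentage points lower (within the scatter) from compound 1 to compound 2 and a number 0 percentage points lower (within the scatter) from compound 3 to compound 4, 0 percentage points apart, within the scatter of two such steps.

Among these four compounds, then, the change carries from one core to the other without a visible difference, and on neither core does the step leave the scatter. This does not show that the swap is harmless in general: compound 3 gives 0.13% and compound 4 gives 0.09%, and the two acetylated compounds also lie close to zero, so the comparison is made entirely among compounds that show almost no inhibition at this concentration. A step that looks small here says little about how the same swap would behave on a core that inhibits strongly, where a real difference between the two groups would have room to appear.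

Cyclohexyl and isobutyl are the only groups shown on the amine nitrogen, so it remains open how a benzyl group, a longer chain or a chain ending in a carboxylic acid would read there. Also open, on these data alone, is whether any compound of this series inhibits meaningfully at a higher concentration.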